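Methylating the thiol of compound 3: expected cytotoxicity

The source may report more compounds than this note shows. Statements on the series, on what has been measured and on what is new or still open speak of the compounds shown alone.

Measured compounds:
compound 1 `CSc1nc(NCCCCCO)c2ccccc2n1` 31400 nM
compound 2 `COc1ccc(CNc2nc(SC)nc3ccccc23)cc1` 93700 nM
compound 3 `Sc1nc(NCc2ccccc2)c2ccccc2n1` 15200 nM

Of the compounds shown here, three share a core and have been tested in a functional assay on HTB-54 cells (Homo sapiens) for cytotoxicity, read by MTT assay, with a stated time of 72 h; a lower number here means a stronger inhibitor of growth, a higher number a weaker inhibitor of growth. Compound 3 gives 15200 nM, the lowest of the three numbers. Compound 1 gives 31400 nM, a gap beyond the scatter, and compound 2 gives 93700 nM, further away still. Going by the values given here, no two of the measured compounds differ in a single place, so no step between them can be read directly.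

Compound 4 `CSc1nc(NCc2ccccc2)c2ccccc2n1` differs from compound 3 by methyl in place of hydrogen on a sulfur. Both compound 1 and compound 2 carry a methylsulfanyl group and give higher numbers than compound 3, so a modest step toward a higher number is expected for compound 4, of about a 2.0-fold higher number from compound 3 to compound 4 (0.30 log units; within the scatter). For compound 4 the estimate is 30000 nM, within 10000 nM to 90000 nM.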

Compound 4, concentration for 50% growth inhibition: 37900 nM
The estimate for compound 4 lay 1.3-fold (0.10 log units) below the measured number; measured number inside the range.
By their numbers in this assay, from the lowest: compound 3; then compounds 1 and 4 (each within the scatter of the next); then compound 2.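

In this assay, going by these compounds alone, methyl in place of hydrogen on the sulfur gives a 2.5-fold higher number from compound 3 to compound 4 (0.40 log units; beyond the scatter), the first direct reading of this position, and the free sulfanyl compound keeps the lower number. Hydrogen in place of methoxy on an aromatic carbon gives a 2.5-fold lower number from compound 2 to compound 4 (0.39 log units; beyond the scatter), so the methoxy group also counts among compounds bearing methylsulfanyl. Phenyl in place of 4-hydroxybutyl on a saturated chain carbon bound to a nitrogen on an aromatic ring gives a 1.2-fold higher number from compound 1 to compound 4 (0.08 log units; within the scatter), a step within the scatter.

Nothing given here explains these steps. Going by these compounds, whether an ethyl group or a longer chain on the sulfur, or an amine in place of the sulfur group, would stay near compound 4 or move toward compound 3 remains open.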